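Amide heteroaryl exchange and expected clearance of compound 4

A few compounds are considered here, and "the series" means these few. Any claim that something is new, unique, unknown or untested is made for them only; others in the source may bear on it.

Compounds measured so far in an ADME assay (liver) for metabolic stability, with Liver microsome (Rattus norvegicus) as the target, using microsomes; a lower number here means slower removal, a higher number faster removal of the compound:
Compound 1 `CN(C(=O)c1csc(-c2cccnc2)n1)c1ccc(OCB2C=Cc3ccccc3N2)cc1` gives only a limit of the assay, > 283 mL/min/kg.
Compound 2 `CN(C(=O)c1ccncc1)c1ccc(OCc2ccc3ccccc3c2)cc1` gives 75 mL/min/kg.
Compound 3 `CN(C(=O)c1cc(-c2ccccc2)n[nH]1)c1ccc(OCc2ccc3ccccc3c2)cc1` gives 6.83 mL/min/kg.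

Within the data shown here, compound 3 thus holds the lowest of the two numbers, and the only measured step, an 11-fold lower number from compound 2 to compound 3 (1.04 log units; beyond the scatter), is large and beyond the scatter. Compound 4 `CN(C(=O)c1csc(-c2cccnc2)n1)c1ccc(OCc2ccc3ccccc3c2)cc1` differs from compound 3 by 2-(pyridin-3-yl)-1,3-thiazol-4-yl in place of 3-phenyl-1H-pyrazol-5-yl on a carbonyl carbon. Among the measured compounds shown here, no measured step covers this exchange. Compound 1 carries the same 2-(pyridin-3-yl)-1,3-thiazol-4-yl group and sits at the limit (the limit of > 283 mL/min/kg in this assay, at which 1 of the 3 values shown sits), whereas compound 3 with the 3-phenyl-1H-pyrazol-5-yl group is the lowest number. Compound 4 is therefore expected to be removed faster, with a step of a 13-fold higher number from compound 3 to compound 4 (1.12 log units; beyond the scatter) in this assay. The estimate for compound 4 is 90 mL/min/kg, with a range from 25 mL/min/kg to 300 mL/min/kg.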

Compound 4, clearance: > 283 mL/min/kg
Compound 4 ended at the assay's limit (the forecaster's own chance of this, stated with the estimate: 25%); middle value at least 3.1-fold (0.49 log units) away from the limit.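

In this assay, placing 2-(pyridin-3-yl)-1,3-thiazol-4-yl on the carbonyl carbon gives an at least 41-fold higher number from compound 3 to compound 4 (1.61 log units; beyond the scatter) and an at least 3.7-fold higher number from compound 2 to compound 4 (0.57 log units; beyond the scatter), so the exchange at this position is now measured on the shared core of compound 2 and compound 3. Compound 4 gives only a limit of the assay: the limit of > 283 mL/min/kg in this assay, at which 2 of the 4 values shown sit. The step between compound 1 and compound 4 cannot be read, since both values are limits.

The compounds shown leave open how far compound 4 lies past that limit. They also leave open how an amine or a carboxylic acid on the 2-(pyridin-3-yl)-1,3-thiazol-4-yl group would read in this assay.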